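Exchanging the amino substituent for 4-methylpiperazin-1-yl

The compounds below may be only part of what the source reports. "The series", "measured", "known", "first", "only" and "open" are said of these compounds alone.

In a functional assay on SK-OV-3 cells (Homo sapiens) for cytotoxicity, read by MTT assay, with a stated time of 3 days (a higher number here means a weaker inhibitor, a lower number a stronger inhibitor), compound 3 `N#Cc1c(Nc2nccs2)nc(SCc2nc3ccccc3[nH]2)nc1-c1ccccc1` gives 5.81 nM and stands level with compound 2 `N#Cc1c(Nc2ccccn2)nc(SCc2nc3ccccc3[nH]2)nc1-c1ccccc1` at 5.81 nM as the highest of the three numbers, while compound 1 `N#Cc1c(NN)nc(SCc2nc3ccccc3[nH]2)nc1-c1ccccc1` gives 2.7 nM as the lowest. Compound 4 `CN1CCN(c2nc(SCc3nc4ccccc4[nH]3)nc(-c3ccccc3)c2C#N)CC1` has 4-methylpiperazin-1-yl in place of (1,3-thiazol-2-yl)amino on an aromatic carbon and awaits measurement. The exchanges at this same place show a 2.2-fold higher number from compound 1 to compound 2 (0.33 log units; beyond the scatter) and a 2.2-fold higher number from compound 1 to compound 3 (0.33 log units; beyond the scatter) and also no change at the digits printed from compound 2 to compound 3 (within the scatter) between the two aromatic groups. Among the measured compounds shown here, no measured compound carries a non-aromatic ring there, so the direction remains open. For the measured compounds named here, the expected outcome is a 1.0-fold higher number from compound 3 to compound 4 (0.01 log units; within the scatter) with no large step in this assay anticipated. Compound 4 is estimated at 6 nM with an expected range from 2.5 nM to 15 nM in this series.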

Compound 4, half-maximal inhibitory concentration: 1600 nM
Beside the measured number, compound 4's estimate is 270-fold (2.43 log units) below it, outside the stated range (above it).
By their numbers in this assay, from the lowest: compound 1; then compounds 2 and 3 (each within the scatter of the next); then compound 4.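

In this assay the entry of 4-methylpiperazin-1-yl on this aromatic carbon brings a 280-fold higher number from compound 3 to compound 4 (2.44 log units; beyond the scatter) and also a 280-fold higher number from compound 2 to compound 4 (2.44 log units; beyond the scatter) and a 590-fold higher number from compound 1 to compound 4 (2.77 log units; beyond the scatter) in the same direction, far beyond any step among the earlier groups. This place therefore responds strongly to the group it carries, which the three earlier compounds did not reveal. Nothing available accounts for the rise. This one exchange removes the hydrogen-bond donor and replaces the aromatic ring with a non-aromatic ring together, so the two remain unseparated. A cyclohexylamino group, keeping the amino hydrogen on a non-aromatic ring, would bear on that question.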